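The source may report more compounds than this note shows. Statements on the series, on what has been measured and on what is new or still open speak of the compounds shown alone.

Three compounds have been measured in a functional assay on HCT-116 cells (Homo sapiens) for inhibition, read by CCK-8 assay, with a stated time of 48 h; a higher number here means a weaker inhibitor, a lower number a stronger inhibitor:

Compound 1 `COc1ccc(CN(C(=O)CSC(=S)N2CCN(C(C)=O)CC2)c2cc(OC)c(OC)c(OC)c2)cc1` gives 1370 nM.
Compound 2 `COc1ccc(CN(C(=O)CSC(=S)N2CCN(C(=O)OC(C)(C)C)CC2)c2cc(OC)c(OC)c(OC)c2)cc1` gives 620 nM.
Compound 3 `COc1ccc(CN(C(=O)CN2CCN(C(C)=O)CC2)c2cc(OC)c(OC)c(OC)c2)cc1` gives only a limit of the assay, > 20000 nM.

Compounds 1 and 2 share one core and differ at a single point, (tert-butoxy in place of methyl on a carbonyl carbon). That change produced a 2.2-fold lower number from compound 1 to compound 2 (0.34 log units; beyond the scatter). Compounds 1 and 3 differ in their cores, (a group of 9 heavy atoms (6 carbon, 2 nitrogen, 1 oxygen; one six-membered non-aromatic ring with 2 hetero atoms) in place of a group of 12 heavy atoms (7 carbon, 2 nitrogen, 1 oxygen, 2 sulfur; one six-membered non-aromatic ring with 2 hetero atoms), on a saturated chain carbon bound to a carbonyl carbon), and that change produced an at least 14-fold higher number from compound 1 to compound 3 (1.16 log units; beyond the scatter). The value of compound 3 is a limit, not a number, as the limit of > 20000 nM in this assay, at which 1 of the 3 values shown sits, shows.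

Compound 4 `COc1ccc(CN(C(=O)CN2CCN(C(=O)OC(C)(C)C)CC2)c2cc(OC)c(OC)c(OC)c2)cc1` has not been measured. It differs from compound 3 by tert-butoxy in place of methyl on a carbonyl carbon, the same change as from compound 1 to compound 2, at the same place. The step is expected to be a step that the limit leaves unreadable from compound 3 to compound 4, resting on a 2.2-fold lower number from compound 1 to compound 2 (0.34 log units; beyond the scatter), which was modest; since compound 3 sits at a limit, compound 4 is expected to stay close to that limit, and the assay may again report only a limit. For compound 4 in this assay the estimate is 25000 nM, expected to fall between 8000 nM and 60000 nM.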

Compound 4, half-maximal inhibitory concentration: 18100 nM
Beside the measured number, compound 4's estimate is 1.4-fold (0.14 log units) above it, and the stated range covers the measured number.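

In this assay, putting tert-butoxy in place of methyl on the carbonyl carbon of the core of compound 3 gives an at least 1.1-fold lower number from compound 3 to compound 4 (0.04 log units; that floor lies within the scatter). Compound 3 stands at a limit of the assay, > 20000 nM, which is not a number, so this step has a floor but no known size. The result therefore does not show that the change carries over from the core of compound 1 with the same size, nor that it behaves differently on the core of compound 3: the same change on two cores in this assay, a 2.2-fold lower number (0.34 log units; beyond the scatter) from compound 1 to compound 2 and an at least 1.1-fold lower number (0.04 log units; that floor lies within the scatter) from compound 3 to compound 4; the limit leaves it open whether they differ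

The compounds shown place only methyl or tert-butoxy on this carbonyl carbon, so it remains open how an amine or a longer chain such as n-butyl in that place would read on either core. Also open, on these data alone, is the true size of the step on the core of compound 3, which would take an actual number for compound 3 rather than a limit.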